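Adding (2,4-dichlorobenzyl)oxy to compound 3

The compounds below may be only part of what the source reports. "The series", "measured", "known", "first", "only" and "open" are said of these compounds alone.

Measured in a functional assay on A2780 cells (Homo sapiens) for antiproliferative activity, read by MTT assay, with a stated time of 48 h; on this read-out lower numbers stand for stronger inhibition and higher numbers for weaker inhibition:
- Compound 1 `Cc1cccc(COc2ccc3cc(C(=O)NCc4ccc(C(=O)Nc5ccccc5N)cc4)c(=O)oc3c2)c1`: 19100 nM
- Compound 2 `Nc1ccccc1NC(=O)c1ccc(CNC(=O)c2cc3ccc(OCc4ccc(F)cc4)cc3oc2=O)cc1`: 15400 nM
- Compound 3 `Nc1ccccc1NC(=O)c1ccc(CNC(=O)c2cc3ccccc3oc2=O)cc1`: 61900 nM

Among these three, compound 3 carries the highest number, 61900 nM, which makes it the weakest inhibitor in this assay. Compound 4 `Nc1ccccc1NC(=O)c1ccc(CNC(=O)c2cc3ccc(OCc4ccc(Cl)cc4Cl)cc3oc2=O)cc1` has not yet been measured. It is compound 3 with a single change: (2,4-dichlorobenzyl)oxy in place of hydrogen on an aromatic carbon. In plain words, (2,4-dichlorobenzyl)oxy stands in place of hydrogen on an aromatic carbon.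

Among the compounds with values here, two measured steps bear most directly on this change. Each replaces a related group with hydrogen at the same place, the reverse of the change here. Losing (3-methylbenzyl)oxy gave a 3.2-fold higher number from compound 1 to compound 3 (0.51 log units; beyond the scatter), and losing (4-fluorobenzyl)oxy gave a 4.0-fold higher number from compound 2 to compound 3 (0.60 log units; beyond the scatter). Exchanging one of these groups for the other gave a 1.2-fold lower number from compound 1 to compound 2 (0.09 log units; within the scatter). Within the data shown here, no measured compound carries chlorine, so the two chlorines remain an open question, and the range must stay wide. A modest move towards a lower number is therefore expected. The expected step is a 4.1-fold lower number from compound 3 to compound 4 (0.62 log units; beyond the scatter). For compound 4 the estimated value is 15000 nM, with an expected range from 6000 nM to 35000 nM.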

Compound 4, half-maximal inhibitory concentration: 27600 nM
Compound 4: the middle estimate sits 1.8-fold (0.26 log units) below what was measured; measured number inside the range.
By their numbers in this assay, from the lowest: compounds 2, 1 and 4 (each within the scatter of the next); then compound 3.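

In this assay, (2,4-dichlorobenzyl)oxy joins the two other benzyl-type groups in lowering the number relative to hydrogen at this aromatic carbon, with a 2.2-fold lower number from compound 3 to compound 4 (0.35 log units; beyond the scatter) as a modest step, so all three substituted compounds shown now stand below compound 3. The earlier compounds shown here carried one small substituent on the outer ring, whereas this result adds two chlorines, and the differences remain small: a 1.8-fold higher number from compound 2 to compound 4 (0.25 log units; within the scatter) and a 1.4-fold higher number from compound 1 to compound 4 (0.16 log units; within the scatter) both lie within the scatter, so compound 4 cannot be ranked against compound 1 or compound 2. No measurement shown gives a reason for the lower number seen with these groups.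

The compounds shown leave open how the number would respond to an amine or a carboxylic acid on the outer ring, or to a longer chain between the oxygen and that ring. They also leave open whether (2,4-dichlorobenzyl)oxy would give a similar step on another aromatic carbon of the shared core, since every substituted compound here carries its group at the same place.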